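Working notes: from compound 3 to compound 4

A few compounds are considered here, and "the series" means these few. Any claim that something is new, unique, unknown or untested is made for them only; others in the source may bear on it.

Values in a functional assay on K562 cells (Homo sapiens) for cytotoxicity, read by MTT assay, with a stated time of 72 h; a higher number here means a weaker inhibitor, a lower number a stronger inhibitor:
- compound 1 `CC1=CCC[C@H]2[C@](C)(CC3=CC(=O)C=CC3=O)[C@@H](C)CC[C@]12C`: 17100 nM
- compound 2 `CC1=CCC[C@H]2[C@](C)(CC3=CC(=O)C=C(N[C@@H](CC(C)C)C(=O)O)C3=O)[C@@H](C)CC[C@]12C`: 11200 nM
- compound 3 `CC1=CCC[C@H]2[C@](C)(CC3=CC(=O)C=C(N[C@@H](C(=O)O)C(C)C)C3=O)[C@@H](C)CC[C@]12C`: 7780 nM

Of these three numbers, that of compound 3 stands clear only of that of compound 1. The measured steps read a 2.2-fold lower number from compound 1 to compound 3 (0.34 log units; beyond the scatter), which is modest, and a 1.4-fold lower number from compound 2 to compound 3 (0.16 log units; within the scatter), which stays within the scatter.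

The next structure is compound 4 `CC1=CCC[C@H]2[C@](C)(CC3=CC(=O)C=C(N[C@@H](C)C(=O)O)C3=O)[C@@H](C)CC[C@]12C`, with 1-carboxyethyl in place of 1-carboxy-2-methylpropyl on an amine nitrogen. Going by the values given here, the closest precedent is the one measured exchange of chain on that amine nitrogen, a 1.4-fold lower number from compound 2 to compound 3 (0.16 log units; within the scatter). Also relevant is the addition of the amino substituents to the core of compound 1, where a 1.5-fold lower number from compound 1 to compound 2 (0.18 log units; within the scatter) lies within the scatter and a 2.2-fold lower number from compound 1 to compound 3 (0.34 log units; beyond the scatter) only just exceeds it. Among the compounds with values here, with steps this small as the only guide, no step beyond the scatter is expected in this assay, and any direction is tentative. The estimated change is a 1.2-fold higher number from compound 3 to compound 4 (0.09 log units; within the scatter). For compound 4 the expected value is 9500 nM, with an estimated range from 4800 nM to 18000 nM.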

Compound 4, half-maximal inhibitory concentration: 15800 nM
Estimate against measurement, compound 4: 1.7-fold (0.22 log units) below, within the range that was stated.
By their numbers in this assay, from the lowest: compounds 3, 2, 4 and 1 (each within the scatter of the next, the first and the last beyond it).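

In this assay, going by these compounds alone, the exchange of 1-carboxy-2-methylpropyl for 1-carboxyethyl on the amine nitrogen gives the first step in chain at this position that lies beyond the scatter, though it remains modest: a 2.0-fold higher number from compound 3 to compound 4 (0.31 log units; beyond the scatter). The other two steps stay within the scatter, with a 1.4-fold higher number from compound 2 to compound 4 (0.15 log units; within the scatter) for hydrogen in place of isopropyl and a 1.1-fold lower number from compound 1 to compound 4 (0.03 log units; within the scatter) for (1-carboxyethyl)amino in place of hydrogen on the double-bonded ring carbon, so the clear separation from compound 1 belongs to compound 3 alone among the amino-substituted compounds, with compound 2 and compound 4 both going against any general effect of adding an amino acid chain. Nothing measured on these compounds accounts for the size of these steps.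

Among the chains shown, the data cannot say whether the branch in compound 3 matters in itself or whether any chain larger than 1-carboxyethyl would serve, and a longer straight chain would help separate the two. Also open, going by these compounds, is how a methyl ester or a primary amide in place of the carboxylic acid on this chain would read in this assay.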